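Swapping methyl for chloro on the phenoxy ring

The source may hold more compounds than are shown below. What is called first, only, known or untested is meant among the compounds shown, and "the series" means these compounds.

Of the compounds shown here, three sharing one core have been tested in a functional assay on A549 cells (Homo sapiens) for cytotoxicity, read by MTT assay, with a stated time of 48 h; a lower number here means a stronger inhibitor, a higher number a weaker inhibitor. Compound 1 `Cc1ccc(-c2csc(NC(=O)COc3ccc(F)cc3)n2)cc1` gives 19300 nM. Compound 2 `O=C(COc1ccc(F)cc1)Nc1nc(-c2ccc(Cl)cc2)cs1` gives 36500 nM; the change chloro in place of methyl on an aromatic carbon made the step of a 1.9-fold higher number from compound 1 to compound 2 (0.28 log units; within the scatter). Compound 3 `Cc1ccc(OCC(=O)Nc2nc(-c3ccc(C)cc3)cs2)cc1` gives 48300 nM, the highest of the three numbers; its core differs from that of compound 1 by methyl in place of fluoro on an aromatic carbon, which made the step of a 2.5-fold higher number from compound 1 to compound 3 (0.40 log units; beyond the scatter).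

Compound 4 `Cc1ccc(-c2csc(NC(=O)COc3ccc(Cl)cc3)n2)cc1` has not yet been measured. It differs from compound 3 by chloro in place of methyl on an aromatic carbon. Going by the values given here, this is the same change as the one from compound 1 to compound 2, although read one bond further out it is 4-methylphenoxy to 4-chlorophenoxy here, whereas there it was 4-methylphenyl to 4-chlorophenyl. Only these two occurrences of the change are present, so the expectation rests on a single precedent. The expected step is a 1.3-fold higher number from compound 3 to compound 4 (0.13 log units; within the scatter), because a 1.9-fold higher number from compound 1 to compound 2 (0.28 log units; within the scatter) stayed within the scatter and a similarly small shift toward a weaker inhibitor seems most likely. Compound 4 is therefore estimated at 65000 nM, with a plausible range from 30000 nM to 130000 nM.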

Compound 4, half-maximal inhibitory concentration: 44000 nM
For compound 4 the middle estimate is 1.5-fold (0.17 log units) above the measured one; measured number inside the range.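

In this assay, turning 4-methylphenoxy into 4-chlorophenoxy gave a 1.1-fold lower number from compound 3 to compound 4 (0.04 log units; within the scatter), while chloro in place of fluoro on that same ring gave a 2.3-fold higher number from compound 1 to compound 4 (0.36 log units; beyond the scatter). The methyl-to-chloro change therefore stayed small on both cores, and the two results do not differ by more than the noise in such measurements: the same change on two cores in this assay, a 1.9-fold higher number (0.28 log units; within the scatter) from compound 1 to compound 2 and a 1.1-fold lower number (0.04 log units; within the scatter) from compound 3 to compound 4, 2.1-fold (0.32 log units) apart, within the scatter of two such steps. Going by these compounds alone, this is only one pair of steps, each too small to give the change a clear direction, so it does not show that the swap would stay this small on other cores, and it does not explain why it was small on these two.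

The compounds shown carry only methyl, fluoro and chloro on these two rings, so the effect of a methoxy group, an amine or a carboxylic acid in those places remains open. Also open, from the compounds shown here alone, is what happens when chloro sits on both rings of the same compound.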